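The compounds below may be only part of what the source reports. "The series", "measured", "known", "first", "only" and "open" are said of these compounds alone.

Of the compounds shown here, two have been measured in a functional assay on PC-3 cells (Homo sapiens) for inhibition, read by MTT assay, with a stated time of 72 h; on this read-out lower numbers stand for stronger inhibition and higher numbers for weaker inhibition. Compound 1 `CCC(=O)O[C@@H](/C(C)=C/[C@@H](C)c1oc(CC)c(C)c(=O)c1C)[C@H](C)[C@@H](OC(=O)CC(C)C)[C@@H](C)c1oc([C@@H](C)[C@@H](O)CC)c(C)c(=O)c1C` gives 3000 nM and compound 2 `CCc1oc([C@H](C)/C=C(\C)[C@H](OC(C)=O)[C@H](C)[C@@H](OC(=O)CC(C)C)[C@@H](C)c2oc([C@@H](C)[C@H](CC)OC(C)=O)c(C)c(=O)c2C)c(C)c(=O)c1C` gives 7000 nM as the higher of the two numbers, which marks the weaker inhibition, and the gap between them lies beyond the usual scatter. Compound 3 `CCC(=O)O[C@@H](/C(C)=C/[C@@H](C)c1oc(CC)c(C)c(=O)c1C)[C@H](C)[C@@H](OC(=O)CC(C)C)[C@@H](C)c1oc([C@@H](C)[C@H](CC)OC(C)=O)c(C)c(=O)c1C` departs from compound 2 by methyl in place of hydrogen on a saturated chain carbon bound to a carbonyl carbon in all, that is, methyl in place of hydrogen on a saturated chain carbon bound to a carbonyl carbon, so that acetoxy becomes propanoyloxy. Going by the values given here, no measured pair shows this change on its own. In this assay a small step toward lower numbers, within the scatter, is expected. The estimated step is a 1.4-fold lower number from compound 2 to compound 3 (0.15 log units; within the scatter) and so stays modest. For compound 3 an estimated 5000 nM is expected, with a range from 2000 nM to 12000 nM in this estimate.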

Compound 3, half-maximal inhibitory concentration: 2000 nM
Beside the measured number, compound 3's estimate is 2.5-fold (0.40 log units) above it; measured number inside the range.
By their numbers in this assay, from the lowest: compounds 3 and 1 (each within the scatter of the next); then compound 2.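

In this assay, going by these compounds alone, the change from acetoxy to propanoyloxy, methyl in place of hydrogen on a saturated chain carbon bound to a carbonyl carbon, gives a 3.5-fold lower number from compound 2 to compound 3 (0.54 log units; beyond the scatter) and is the first single-place change here seen to matter beyond the scatter. The other comparison, acetyl in place of hydrogen on an oxygen on a saturated carbon, gives a 1.5-fold lower number from compound 1 to compound 3 (0.18 log units; within the scatter) and so does not separate the acetoxy group from the free hydroxyl at that oxygen. Nothing available here accounts for either step.

On these data alone, whether a longer acyl chain such as butanoyloxy, or a benzoyloxy group, in the place of the propanoyloxy would carry the step further stays open. Also open, as far as these compounds go, is whether an amine or a carboxylic acid on that chain would be tolerated in this read-out.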